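The source may report more compounds than this note shows. Statements on the series, on what has been measured and on what is new or still open speak of the compounds shown alone.

Measured compounds:
Compound 1 `CC(C)CCNC(=O)c1ccccc1[Se][Se]c1ccccc1C(=O)NCCC(C)C`: > 40000 nM (a limit)
Compound 2 `C=CCNC(=O)c1ccccc1[Se][Se]c1ccccc1C(=O)NCC=C`: 20400 nM
Compound 3 `C=CCn1[se]c2ccccc2c1=O`: 10300 nM

Of the compounds shown here, three have been tested in a functional assay on DU-145 cells (Homo sapiens) for cytotoxicity, read by sulforhodamine B assay, with a stated time of 24 h; on this read-out lower numbers stand for stronger inhibition and higher numbers for weaker inhibition. Compound 1 gives > 40000 nM, which is a limit of the assay and not a number, (the limit of > 40000 nM in this assay, at which 1 of the 3 values shown sits). Compound 2 gives 20400 nM. Compound 3 gives 10300 nM, the lower of the two numbers, but its gap to compound 2 falls within the scatter, so the two cannot be ordered.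

Compound 4 `CC(C)CCn1[se]c2ccccc2c1=O` has not yet been measured. It differs from compound 3 by isobutyl in place of vinyl on a saturated chain carbon bound to an aromatic nitrogen, or, cut one bond further out, allyl to isopentyl. Going by the values given here, no measured pair follows this change on the core of compound 3. Among the diselenides, compound 2 carries the allyl chain. Compound 1, its isopentyl counterpart, reaches only a limit in this assay.

In this assay the step is expected to be a modest weakening, a 1.7-fold higher number from compound 3 to compound 4 (0.24 log units; within the scatter). Compound 4 is estimated at 18000 nM, with a range from 7000 nM to 45000 nM.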

Compound 4, half-maximal inhibitory concentration: 30400 nM
Estimate against measurement, compound 4: 1.7-fold (0.23 log units) below; low and high end bracket the measured number.
By their numbers in this assay, from the lowest: compounds 3, 2 and 4 (each within the scatter of the next, the first and the last beyond it). At a limit, above all of these: compound 1.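

Going by these compounds alone, on the core of compound 3, this is the first measured pair for the change from allyl to isopentyl, and in this assay it gives a 3.0-fold higher number from compound 3 to compound 4 (0.47 log units; beyond the scatter). Among the diselenides the same change could not be given a size: compound 1 gives > 40000 nM, which is a limit of the assay and not a number. On the shared core, the isopentyl chain of compound 4 still gives a measured number, but little room remains above it: the limit of > 40000 nM in this assay, at which 1 of the 4 values shown sits.

The step changes chain length and removes the double bond at once, so the compounds shown do not tell which of the two goes with the higher number, and a saturated propyl chain in the same place would separate them. Also open is how this core responds to a chain that ends in an amine or a carboxylic acid, since every chain shown here is built from carbon alone.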